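Swapping a Nitrile for Chlorine on the Phenyl Arm

This account rests on a few compounds, and the source may have more. Where it says the series, first, only, none or still open, it means among the compounds named here.

Measured so far:
Compound 1 `Cc1ccsc1C(c1c(C)noc1C)N1CCN(c2ncnc3c2cnn3-c2ccccc2)CC1`: > 25000 nM
Compound 2 `N#Cc1cccc(C(c2ccccc2)N2CCN(c3ncnc4c3cnn4-c3ccccc3)CC2)c1`: > 25000 nM

Both results come from a functional assay on cells (Rhabdomyosarcoma cell, Homo sapiens) for cytotoxicity; a lower number here means a stronger inhibitor, a higher number a weaker inhibitor. For compound 2 the value > 25000 nM is a limit of the assay, not a number. Compound 1 likewise gives only a limit. Among the measured compounds shown here, compound 2 therefore stands at the limit of > 25000 nM in this assay, at which 2 of the 2 values shown sit, and no step between two measured compounds exists that would show how this series responds to a change at the phenyl arm.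

Compound 3 `Clc1ccc(C(c2ccccc2)N2CCN(c3ncnc4c3cnn4-c3ccccc3)CC2)cc1` has not yet been measured. It differs from compound 2 by 4-chlorophenyl in place of 3-cyanophenyl on a saturated chain carbon bound to an amine nitrogen in a ring and an aromatic carbon. With the two measured compounds both at the limit, no step beyond the scatter in this assay is expected in either direction, and compound 3 will most likely also return a limit. Compound 3 is estimated at 30000 nM, with a range from 12000 nM to 80000 nM. That corresponds to an expected step that the limit leaves unreadable from compound 2 to compound 3.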

Compound 3, half-maximal inhibitory concentration: > 25000 nM
Compound 3 was reported as a limit (the forecaster's own chance of this, stated with the estimate: 80%); the middle value lies beyond the limit too.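

Compound 3 gives only a limit, as compound 2 does, so no step between compound 2 and compound 3 can be read in this assay: the limit of > 25000 nM in this assay, at which 3 of the 3 values shown sit.

The compounds shown leave open whether 4-chlorophenyl and 3-cyanophenyl differ at all here, and which change would give a measurable value.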